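Lengthening the Methyl Chain in Compound 3

The compounds below may be only part of what the source reports. "The series", "measured", "known", "first", "only" and "open" are said of these compounds alone.

Measured in a functional assay for inhibition, with Cavia porcellus as the target; a higher number here means a weaker inhibitor, a lower number a stronger inhibitor:
- compound 1 `CCO/C(O)=C1\C(C)=NC(C)=C([N+](=O)[O-])C1c1ccccn1`: 5000 nM
- compound 2 `CC1=NC(C)=C([N+](=O)[O-])C(c2ccccn2)/C1=C(\O)OC(C)(C)C`: 1930 nM
- compound 3 `CO/C(O)=C1\C(C)=NC(C)=C([N+](=O)[O-])C1c1ccccn1`: 212000 nM

Compound 3 has the highest number of the three, which makes it the weakest inhibitor here. Compound 4 `COCCO/C(O)=C1\C(C)=NC(C)=C([N+](=O)[O-])C1c1ccccn1` differs from it by methoxymethyl in place of hydrogen on a saturated chain carbon bound to an oxygen on an unsaturated carbon, which turns methyl to 2-methoxyethyl. Among the measured compounds shown here, two measured steps bear on this change, both large: a 42-fold higher number from compound 1 to compound 3 (1.63 log units; beyond the scatter) and a 110-fold higher number from compound 2 to compound 3 (2.04 log units; beyond the scatter). Each ends at the methyl group of compound 3, so the change to compound 4 runs the opposite way, towards a larger group. For the measured compounds named here, no measured compound carries 2-methoxyethyl, so the range stays wide. A large fall in this assay is expected, an estimated 30-fold lower number from compound 3 to compound 4 (1.48 log units; beyond the scatter). The estimated value for compound 4 is 7000 nM, with an expected range of 1500 nM to 50000 nM.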

Compound 4, half-maximal inhibitory concentration: 94700 nM
Compound 4: the middle estimate sits 14-fold (1.13 log units) below what was measured, outside the stated range (above it).
By their numbers in this assay, from the lowest: compound 2; then compound 1; then compound 4; then compound 3.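

In this assay the 2-methoxyethyl group of compound 4 gains only a little over methyl (a 2.2-fold lower number from compound 3 to compound 4 (0.35 log units; beyond the scatter)), so added length alone does not match what ethyl or tert-butyl gives. Methoxy on the saturated chain costs far more (a 19-fold higher number from compound 1 to compound 4 (1.28 log units; beyond the scatter)), and the gap to tert-butyl stays large (a 49-fold higher number from compound 2 to compound 4 (1.69 log units; beyond the scatter)), so compound 4 shows that a larger group here need not give a lower number. Nothing measured here explains this result.

As far as these compounds go, whether a plain propyl or butyl chain would do better than 2-methoxyethyl remains open, as does the effect of an amine at the chain end.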